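Removing One Core Chloro From Compound 1

The source may report more compounds than this note shows. Statements on the series, on what has been measured and on what is new or still open speak of the compounds shown alone.

Compound 1 `ClCc1cccc(Cn2cnc3c(Cl)nc(Cl)nc32)c1` and compound 2 `ClCc1ccc(Cn2cnc3c(Cl)nc(Cl)nc32)cc1` have been measured in a functional assay on NCI-H522 cells (Homo sapiens) for cytotoxicity, read by sulforhodamine B assay, with a stated time of 48 h; on this read-out higher numbers stand for weaker inhibition of growth and lower numbers for stronger inhibition of growth. Compound 1 gives 2690 nM in this assay, the lower of the two numbers; compound 2 gives 22400 nM, a gap beyond the scatter. Compound 3 `ClCc1cccc(Cn2cnc3c(Cl)ncnc32)c1` is not yet measured. It differs from compound 1 by hydrogen in place of chloro on an aromatic carbon, on an aromatic carbon between two ring nitrogen atoms of the shared core. For the measured compounds named here, no measured pair shows this change, so the step is expected to be small, a modest weakening in this assay at most. Compound 3 is therefore estimated at 4500 nM, within 1500 nM to 14000 nM. This corresponds to an expected step of a 1.7-fold higher number from compound 1 to compound 3 (0.22 log units; within the scatter).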

Compound 3, concentration for 50% growth inhibition: 18600 nM
Estimate against measurement, compound 3: 4.1-fold (0.62 log units) below; measured number outside the range, above it.
By their numbers in this assay, from the lowest: compound 1; then compounds 3 and 2 (each within the scatter of the next).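

In this assay, hydrogen in place of chloro on this aromatic carbon between two ring nitrogen atoms gives a 6.9-fold higher number from compound 1 to compound 3 (0.84 log units; beyond the scatter) and so costs growth inhibition beyond the scatter. For the compounds shown here, this is the first reading on a change to the shared core, since compound 1 and compound 2 share that core with both chloro groups in place. Nothing measured here explains the step.

From the compounds shown here alone, whether an amine, a methoxy group or a longer chain at this carbon would hold the number of compound 1 remains open. Going by these compounds, the contribution of the remaining chloro on the core also remains open.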